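Compound 1 Trades Trifluoromethyl for Fluoro

The compounds below may be only part of what the source reports. "The series", "measured", "known", "first", "only" and "open" are said of these compounds alone.

In a functional assay on HepG2 cells (Homo sapiens) for cytotoxicity, read by MTT assay, with a stated time of 72 h (on this read-out higher numbers stand for weaker inhibition and lower numbers for stronger inhibition), compound 1 (`CNC(=O)c1cc(Oc2ccc(NC(=O)c3nn(-c4ccccc4C(F)(F)F)c(=O)cc3C)cc2F)ccn1`) gives only a limit, > 40000 nM, and no number. Its standing on the figures at hand is thus (the limit of > 40000 nM in this assay, at which 1 of the 2 values shown sits).

For the measured compounds named here, the one measured neighbour is compound 2 (`CNC(=O)c1cc(Oc2ccc(NC(=O)c3nn(-c4cccc(F)c4)c(=O)cc3C)cc2F)ccn1`), which carries 3-fluorophenyl in place of 2-(trifluoromethyl)phenyl and gives 10200 nM. As far as these compounds go, that change amounts to an at least 3.9-fold lower number from compound 1 to compound 2 (0.59 log units; beyond the scatter), a step beyond the scatter, and its true size stays open on one side.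

Compound 3 (`CNC(=O)c1cc(Oc2ccc(NC(=O)c3nn(-c4ccccc4F)c(=O)cc3C)cc2F)ccn1`) keeps the core of compound 1 and differs from it in one place: fluoro in place of trifluoromethyl on an aromatic carbon. In words, this is fluoro in place of trifluoromethyl on an aromatic carbon, ortho to a large group, or 2-(trifluoromethyl)phenyl to 2-fluorophenyl.

Going by the values given here, the only measured guide is compound 2 with its an at least 3.9-fold lower number from compound 1 to compound 2 (0.59 log units; beyond the scatter), which also leaves a fluorophenyl in the place of the original group, so a step of similar size and direction is expected here. The estimated change is an at least 2.8-fold lower number from compound 1 to compound 3 (0.45 log units; beyond the scatter), toward stronger inhibition. Compound 3 is expected at 14000 nM, with an estimated range of 5000 nM to 38000 nM.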

Compound 3, half-maximal inhibitory concentration: > 40000 nM
Compound 3: no number, only a limit; the forecaster's own chance of this, stated with the estimate: 15%; at least 2.8-fold (0.45 log units) between middle value and limit.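

In this assay compound 3 gives > 40000 nM, which is a limit of the assay and not a number, so fluoro in place of trifluoromethyl on this aromatic carbon, ortho to a large group, does not by itself bring a measurable value, and compound 3 joins compound 1 at the same limit: the limit of > 40000 nM in this assay, at which 2 of the 3 values shown sit.

The step between compound 1 and compound 3 cannot be read, since both values are limits. What can be read is that a fluorophenyl group alone does not account for the number seen with compound 2, as the 2-fluorophenyl and 3-fluorophenyl groups are separated by an at least 3.9-fold higher number from compound 2 to compound 3 (0.59 log units; beyond the scatter), so among these three compounds the place of the fluoro on the ring matters and only the 3-fluorophenyl group gives a number.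

As far as these compounds go, how far compound 1 and compound 3 lie beyond the limit, and so whether trifluoromethyl and fluoro differ at all in this place, stays open. Also open, from the compounds shown here alone, is whether an amine or a carboxylic acid in place of the fluoro of compound 2 would lower or raise the number.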